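Phenoxyacetamide series: substituent size on the aryl ether

A few compounds are considered here, and "the series" means these few. Any claim that something is new, unique, unknown or untested is made for them only; others in the source may bear on it.

Measured compounds:
compound 1 `Cc1cccc(OCC(=O)Nc2ccc(OCC(=O)O)c(F)c2)c1`: 108 nM
compound 2 `Cc1ccc(OCC(=O)Nc2ccc(OCC(=O)O)c(F)c2)cc1`: 148 nM

In a functional assay on CHO cells for agonist activity at Free fatty acid receptor 1 (Homo sapiens), read by FLIPR (on this read-out higher numbers stand for an effect only at larger amounts of compound and lower numbers for an effect already at smaller amounts), compound 1 gives 108 nM. Compound 2, which carries 4-methylphenyl in place of 3-methylphenyl on an oxygen on a saturated carbon, gives 148 nM. The step of a 1.4-fold higher number from compound 1 to compound 2 (0.14 log units; within the scatter) is within the scatter, so compound 1 and compound 2 stand level on the numbers shown.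

Compound 3 `CC(C)(C)c1cccc(OCC(=O)Nc2ccc(OCC(=O)O)c(F)c2)c1` is not yet measured. It differs from compound 1 by tert-butyl in place of methyl on an aromatic carbon. Within the data shown here, no measured step enlarges a substituent on this ring; the one step available, from compound 1 to compound 2, only moves the methyl and stays within the scatter. It therefore gives no direction for the change to tert-butyl, and any expectation rests on the unchanged shared core alone. The estimated step of a 1.8-fold lower number from compound 1 to compound 3 (0.26 log units; within the scatter) is taken as modest, with direction uncertain. Compound 3 is expected to give 60 nM, within a range from 20 nM to 200 nM.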

Compound 3, half-maximal effective concentration: 122 nM
For compound 3 the middle estimate is 2.0-fold (0.31 log units) below the measured one, within the range that was stated.
By their numbers in this assay, from the lowest: compounds 1, 3 and 2 (each within the scatter of the next).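

In this assay, tert-butyl in place of methyl on an aromatic carbon, meta to a large group, gives a 1.1-fold higher number from compound 1 to compound 3 (0.05 log units; within the scatter). This place in the series therefore takes four carbons where compound 1 has one, and compound 1 and compound 3 stand level on the numbers shown; earlier, the only step moved the methyl and did not change its size. No measurement on hand accounts for this level result.

The compounds shown carry only the two carbon-only groups at this place, methyl and tert-butyl, so they leave open whether the level holds for an amine, a carboxylic acid or a longer chain there. On these data alone, whether a phenyl ring in the same place would keep the number level with compound 1 also remains open.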